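Morpholinyl amide on the indole-bearing core: an expectation

The compounds below may be only part of what the source reports. "The series", "measured", "known", "first", "only" and "open" are said of these compounds alone.

Compound 2 `CCOC(=O)/C=C/c1ccncc1-c1ccc2cc[nH]c2c1` is the reference point here. In an assay on a protein complex for inhibition of CDK8/Cyclin C (Homo sapiens), with a stated time of 1 h, tested at 10 uM (a lower number here means less inhibition, a higher number more inhibition at the concentration tested (going by the name of the read-out)), compound 2 gives 104%, which places it at the top of the three numbers measured, though not clearly apart from its nearest neighbour. Compound 1 `CNC(=O)/C=C/c1ccncc1-c1ccc2cc[nH]c2c1` gives 103% in this assay, and the step of a number 1 percentage points higher from compound 1 to compound 2 (within the scatter) shows that the two are indistinguishable. Compound 3 `O=C(/C=C/c1ccncc1-c1ccc2cccnc2c1)N1CCOCC1` gives 33%; its value sits far below that of compound 2, but compound 3 differs from compound 2 in its core as well as in the group on the carbonyl carbon, so no single step can be read from that pair.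

Compound 4 `O=C(/C=C/c1ccncc1-c1ccc2cc[nH]c2c1)N1CCOCC1` keeps the core of compound 2 and changes only the group on the carbonyl carbon: morpholin-4-yl in place of ethoxy on a carbonyl carbon. For the measured compounds named here, the one step that bears directly on this change is a number 1 percentage points higher from compound 1 to compound 2 (within the scatter), which was within the scatter and suggests that the group on the carbonyl carbon can be exchanged without a large shift in this assay. Compound 3 offers a caution, but its core is different. Compound 4 is therefore expected to show a step of a number 14 percentage points lower from compound 2 to compound 4 (beyond the scatter), most likely none beyond the scatter. The estimate for compound 4 is 90%, with a range from 55% to 105%.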

Compound 4, a percentage reported as inhibition, at one concentration (the size of the read-out at that concentration, not a potency): 102%
The estimate for compound 4 lay 12 percentage points below the measured number; the range from low to high includes it.
By their numbers in this assay, from the lowest: compound 3; then compounds 4, 1 and 2 (each within the scatter of the next).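

In this assay, the change to morpholin-4-yl gives a step of a number 2 percentage points lower from compound 2 to compound 4 (within the scatter) and a step of a number 1 percentage points lower from compound 1 to compound 4 (within the scatter), so a group with a six-membered non-aromatic ring on the carbonyl carbon fits the pattern that the earlier exchange of methylamino and ethoxy had only begun to suggest: across these three groups on this core, the read-out stays level. Compound 3 carries the same morpholin-4-yl group on a different core and gives 33%, whereas compound 4 gives 102%. For the compounds shown here, the core is the one place where this pair differs. No supporting measurement bears on why this position accepts all three groups.

On these data alone, whether the same holds for a carboxylic acid, a piperazine ring or a longer chain on the carbonyl carbon remains open. Compounds 1, 2 and 4 were each read at a single concentration, so their numbers leave open whether they differ in potency at lower concentrations.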